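Swapping a Carboxy for a Nitro Group on the Core

The source may hold more compounds than are shown below. What is called first, only, known or untested is meant among the compounds shown, and "the series" means these compounds.

Compound 1 `O=C(c1ccncc1)N1N=C(c2cc3ccccc3o2)CC1c1ccccc1` and compound 2 `CCn1cc(C(=O)N2N=C(c3cc4ccccc4o3)CC2c2ccccc2C(=O)O)c(=O)c2ccc(C)nc21` share a core and were both examined in an ADME assay on Vero cells (Chlorocebus sabaeus) for cytotoxicity, read by MTT assay, with a stated time of 72 h; on this read-out lower numbers stand for stronger inhibition and higher numbers for weaker inhibition. In this assay compound 1 gave a reading that is a limit of the assay rather than a number, > 209000 nM. Compound 2 likewise reached only a limit in this assay, > 196000 nM. On the values shown, compound 2 therefore stands at one of two limits, as noted in the limit of > 196000 nM in this assay, at which 1 of the 2 values shown sits, and (the limit of > 209000 nM in this assay, at which 1 of the 2 values shown sits), and no ordering between the two compounds can be read from them, since neither gives a true number.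

Compound 3 `CCn1cc(C(=O)N2N=C(c3cc4ccccc4o3)CC2c2ccccc2[N+](=O)[O-])c(=O)c2ccc(C)nc21` is the compound not yet measured. It differs from compound 2 in one place: nitro in place of carboxy on an aromatic carbon. Within the data shown here, no measured pair in this set shows the effect of such a change, so there is no step from which a size or direction could be taken. For compound 3 the expected value in this assay is 200000 nM, with a likely range from 80000 nM to 500000 nM. The step this implies from compound 2 to compound 3 is expected to be a step that the limit leaves unreadable from compound 2 to compound 3, none beyond the scatter, and the result is quite likely to come back once more as a limit.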

Compound 3, half-maximal inhibitory concentration: > 85400 nM
Compound 3: no number, only a limit; the forecaster's own chance of this, stated with the estimate: 70%; the middle value is on the limit's open side.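

Among these compounds, compound 2 and compound 3 each gave only a limit of the assay in this assay, not a number, and no step between them can be read. The compounds shown leave open whether nitro in place of carboxy changes the reading at all, and at what concentration compound 1, compound 2 or compound 3 would reach half-maximal inhibition.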